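A few compounds are considered here, and "the series" means these few. Any claim that something is new, unique, unknown or untested is made for them only; others in the source may bear on it.

Measured so far:
compound 1, `CC(=O)/C(=C/c1c(-c2ccccc2)[nH]c2ccccc12)C(=O)c1ccccc1`: 12000 nM
compound 2, `CCOC(=O)/C(=C/c1c(-c2ccccc2)[nH]c2ccccc12)C(=O)c1ccc([N+](=O)[O-])cc1`: 2400 nM
compound 3, `COCCOC(=O)/C(C#N)=C/c1c(-c2ccccc2)[nH]c2ccccc12`: 2200 nM

All three were tested in a functional assay on WIL2-NS cells (Homo sapiens) for cytotoxicity, read by MTT assay, with a stated time of 96 h; on this read-out lower numbers stand for an effect already at smaller amounts and higher numbers for an effect only at larger amounts of compound. Compound 2 gives 2400 nM, the second highest of the three numbers. Compound 3 with 2200 nM lies within the scatter of it, while compound 1 with 12000 nM stands beyond the scatter, at a higher number. Compound 4, `CCOC(=O)/C(=C/c1c(-c2ccccc2)[nH]c2ccccc12)C(=O)c1ccccc1`, is not yet measured. It differs from compound 2 in a single place: hydrogen in place of nitro on an aromatic carbon, so the (4-nitrophenyl)carbonyl of compound 2 becomes a benzoyl. Among the compounds with values here, no measured pair shows this change alone, so its effect cannot be read from the numbers at hand. The expected step is modest, a 1.9-fold higher number from compound 2 to compound 4 (0.27 log units; within the scatter), most likely toward a higher number. Compound 4 is therefore estimated at 4500 nM, with a range from 1500 nM to 14000 nM.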

Compound 4, half-maximal effective concentration: 12000 nM
The estimate for compound 4 lay 2.7-fold (0.43 log units) below the measured number, and the stated range covers the measured number.
By their numbers in this assay, from the lowest: compounds 3 and 2 (each within the scatter of the next); then compounds 1 and 4 (each within the scatter of the next).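

In this assay, hydrogen in place of nitro gives a 5.0-fold higher number from compound 2 to compound 4 (0.70 log units; beyond the scatter) and so shows that this aromatic carbon responds to the change, at least in this pair. Ethoxy in place of methyl on a carbonyl carbon, by contrast, gives no change at the digits printed from compound 1 to compound 4 (within the scatter) and thus no sign of a response at that site. Nothing at hand explains either result. Going by these compounds, whether an amine or a carboxylic acid on the same aromatic carbon would match the hydrogen or the nitro remains open, as does whether a longer chain on that carbonyl carbon would still leave the number unchanged.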